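Naphthalen-1-yl for benzyl on an amide nitrogen: an unreadable start

This account rests on a few compounds, and the source may have more. Where it says the series, first, only, none or still open, it means among the compounds named here.

Compound 1 `COc1ccc(CNC(=O)COc2ccc3cc(C(O)(C(F)(F)F)C(F)(F)F)c(O)cc3c2)cc1OC` gives > 20000 nM in an assay on isolated protein for inhibition of tyrosine-protein phosphatase non-receptor type 13 (Homo sapiens), read by spectrophotometry (a lower number here means a stronger inhibitor, a higher number a weaker inhibitor), which is a limit of the assay and not a number. Compound 2 `O=C(COc1ccc2cc(C(O)(C(F)(F)F)C(F)(F)F)c(O)cc2c1)NCc1ccccc1` gives > 20000 nM in this assay, again a limit rather than a number.

Compound 2 therefore stands at the upper edge of what the assay can report; no measured number places it anywhere within the range. Within the data shown here, both compounds sit at that same edge (the limit of > 20000 nM in this assay, at which 2 of the 2 values shown sit), so the one measured step, a step that the two limits leave unreadable from compound 1 to compound 2, cannot be read in size or direction.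

Compound 3 `O=C(COc1ccc2cc(C(O)(C(F)(F)F)C(F)(F)F)c(O)cc2c1)Nc1cccc2ccccc12` differs from compound 2 by naphthalen-1-yl in place of benzyl on an amide-type nitrogen. Among the measured compounds shown here, no measured step touches a change on this amide nitrogen, and the only measured step is itself unreadable, so nothing here supports an expected step of any size or direction beyond the scatter.

Compound 3 is thus expected to sit again at the limit of this assay, with an estimate of 20000 nM and a range from 5000 nM to 60000 nM. The expected step is a number no higher from compound 2 to compound 3 (the limit leaves the size open), essentially no readable change.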

Compound 3, half-maximal inhibitory concentration: > 20000 nM
Compound 3: a limit, no number (the forecaster's own chance of this, stated with the estimate: 70%); the middle value lies on the limit itself.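

Compound 3 gives > 20000 nM in this assay, which is a limit of the assay and not a number. No step among compound 1, compound 2 and compound 3 can be read, in size or in direction: the limit of > 20000 nM in this assay, at which 3 of the 3 values shown sit.

The compounds shown leave open whether any change on the amide-type nitrogen alters inhibition at all.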